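The compounds below may be only part of what the source reports. "The series", "measured", "known", "first", "only" and "open" are said of these compounds alone.

In a functional assay on MGC-803 cells (Homo sapiens) for antiproliferative activity, read by CCK-8 assay, with a stated time of 72 h, tested at 8 uM (on this read-out lower numbers stand for a weaker effect and higher numbers for a stronger effect at the one concentration tested), the three measured compounds give the following numbers. Compound 1 `Nc1ccccc1NC(=O)c1ccc(CSC(=S)N2CCN(c3ccc(Cl)cc3)CC2)cc1` gives 17.2%. Compound 2 `Nc1ccccc1NC(=O)c1ccc(CSC(=S)N2CCN(c3ccncc3)CC2)cc1` gives 87.1%. Compound 3 `Nc1ccccc1NC(=O)c1ccc(CSC(=S)N2CCN(c3cccnc3)CC2)cc1` gives 76.9%.

Compound 3 stands second highest of these three: the step of a number 10.2 percentage points lower from compound 2 to compound 3 (beyond the scatter) leaves it somewhat under compound 2, while the step of a number 59.7 percentage points higher from compound 1 to compound 3 (beyond the scatter) sets it far above compound 1. Compound 4 `Cc1ccc(N2CCN(C(=S)SCc3ccc(C(=O)Nc4ccccc4N)cc3)CC2)cc1` differs from compound 3 in one place: 4-methylphenyl in place of pyridin-3-yl on an amine nitrogen in a ring. Among the compounds with values here, two measured steps bear on this change. Both a number 69.9 percentage points higher from compound 1 to compound 2 (beyond the scatter) and a number 59.7 percentage points higher from compound 1 to compound 3 (beyond the scatter) show that swapping the carbon-only aromatic ring of compound 1 for a ring with one nitrogen raised the read-out by a large amount. Compound 4 takes that road backwards, returning to a six-membered aromatic ring of carbon only, so a large fall beyond the scatter is expected, a number 51.9 percentage points lower from compound 3 to compound 4 (beyond the scatter), bringing it close to compound 1. The read-out for compound 4 is therefore estimated at 25%, with a likely range from 8% to 55%.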

Compound 4, a percentage reported as inhibition, at one concentration (the size of the read-out at that concentration, not a potency): 19.8%
Beside the measured number, compound 4's estimate is 5.2 percentage points above it, within the range that was stated.
By their numbers in this assay, from the lowest: compounds 1 and 4 (each within the scatter of the next); then compound 3; then compound 2.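

In this assay the change to 4-methylphenyl brings a large loss, seen both in a number 57.1 percentage points lower from compound 3 to compound 4 (beyond the scatter) and in a number 67.3 percentage points lower from compound 2 to compound 4 (beyond the scatter). The low read-out on this amine nitrogen is therefore not tied to the chloro group, since methyl in place of chloro gives a number 2.6 percentage points higher from compound 1 to compound 4 (within the scatter) and leaves the two carbon-only rings indistinguishable; among these four compounds, both rings with a nitrogen read high and both carbon-only rings read low, and no compound goes against this. Nothing measured here explains this split.

From the compounds shown here alone, it remains open whether a carbon-only ring could regain the read-out if it carried a different group, such as a hydroxyl, an amine or a carboxylic acid. Going by these compounds, the behaviour of pyridin-2-yl, or of a pyrimidine ring with two nitrogens, also remains unknown.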